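From chloro to methyl on a shared core

The source may report more compounds than this note shows. Statements on the series, on what has been measured and on what is new or still open speak of the compounds shown alone.

Compound 1, `Cc1nc(Nc2cccc(Cl)c2)sc1C(=O)/C=C/c1ccccc1`, in a functional assay on PC-3 cells (Homo sapiens) for cytotoxicity, read by MTT assay (a lower number here means a stronger inhibitor, a higher number a weaker inhibitor), gives > 25000 nM, which is a limit of the assay rather than a number.
Compound 2, `Cc1nc(Nc2cccc(Cl)c2)sc1C(=O)/C=C/c1ccc(Cl)cc1`, in this assay gives > 25000 nM, again a limit of the assay and not a number.

Within the data shown here, compound 1 thus stands only at a limit in this assay, with no number to place it, and the one further value shown is a limit as well: the limit of > 25000 nM in this assay, at which 2 of the 2 values shown sit. The change from compound 1 to compound 3, `Cc1cccc(Nc2nc(C)c(C(=O)/C=C/c3ccccc3)s2)c1`, is methyl in place of chloro on an aromatic carbon. Among the measured compounds shown here, only one measured step is at hand, a step that the two limits leave unreadable from compound 1 to compound 2, a step between two limits whose size cannot be read, and it concerns a different place on the molecule, so it says little about the change in question. With both measured values sitting at the limit, no size or direction beyond the scatter can be read for the new step. Compound 3 is therefore expected to sit near the same limit, estimated at 40000 nM with a range from 15000 nM to 150000 nM. The expected step that the limit leaves unreadable from compound 1 to compound 3 is essentially none.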

Compound 3, half-maximal inhibitory concentration: 11700 nM
For compound 3 the middle estimate is 3.4-fold (0.53 log units) above the measured one; the measured number lies below the stated range.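

Changing the group on this aromatic carbon, from 3-chlorophenyl to 3-methylphenyl, gives an at least 2.1-fold lower number from compound 1 to compound 3 (0.32 log units; beyond the scatter). The earlier pair showed no readable change, whereas here, in this assay, compound 3 gives a real number, 11700 nM, so this position on the shared core can affect the read-out even with a swap of one heavy atom for another. The true size of the step remains unknown, since one end of it rests on a limit of the assay and not on a number: the limit of > 25000 nM in this assay, at which 2 of the 3 values shown sit.

The compounds shown leave open whether the effect belongs to methyl in particular or would also appear with a longer chain such as ethyl, or with an amine or a methoxy group at the same place. They also leave open whether methyl here would give a readable number when the chloro of compound 2 is present on the other aromatic ring.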